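The source may hold more compounds than are shown below. What is called first, only, known or untested is meant among the compounds shown, and "the series" means these compounds.

Among the measured compounds shown here, in a functional assay on Ehrlich cells (Mus musculus) for cytotoxicity, read by trypan blue exclusion, with a stated time of 2 h, tested at 25 ug/mL (on this read-out lower numbers stand for a weaker effect and higher numbers for a stronger effect at the one concentration tested), compound 2 `N#CC1=C(N)N(c2ccc(S(N)(=O)=O)cc2)C2=C(CCCC2)C1c1ccc([N+](=O)[O-])cc1` gives 5%; its only neighbour, compound 1 `N#CC1=C(N)N(c2ccc(S(N)(=O)=O)cc2)C2=C(CCCC2)C1c1cccc([N+](=O)[O-])c1`, gives 1% in this assay, and the step of a number 4 percentage points higher from compound 1 to compound 2 (within the scatter) places the two numbers within the scatter of each other. Compound 3 `N#CC1=C(N)N(c2ccc(S(N)(=O)=O)cc2)C2=C(CCCC2)C1c1ccccc1Cl` differs from compound 2 by 2-chlorophenyl in place of 4-nitrophenyl on a saturated ring carbon. For the measured compounds named here, the one measured step, a number 4 percentage points higher from compound 1 to compound 2 (within the scatter), swapped 4-nitrophenyl for 3-nitrophenyl only and stayed within the scatter; no measured step introduces a 2-chlorophenyl group. With both measured numbers low, the expected step is a number 1 percentage points lower from compound 2 to compound 3 (within the scatter), none beyond the scatter. Compound 3 is therefore estimated at 4%, between 0% and 14%.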

Compound 3, a percentage reported as activity, at one concentration (the size of the read-out at that concentration, not a potency): 0%
Estimate against measurement, compound 3: 4 percentage points above, and the stated range covers the measured number.
By their numbers in this assay, from the lowest: compounds 3, 1 and 2 (each within the scatter of the next).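

In this assay, replacing either nitrophenyl group with 2-chlorophenyl on this saturated ring carbon gives a number 5 percentage points lower from compound 2 to compound 3 (within the scatter) and a number 1 percentage points lower from compound 1 to compound 3 (within the scatter). The earlier pair showed only a move of the nitro group around the phenyl ring, whereas these steps show that an entirely different substituent also leaves the read-out within the scatter. No available evidence explains this result. It remains open whether an amine or a carboxylic acid at this saturated ring carbon would give a read-out beyond the scatter of these compounds.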